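Methyl on the Far Phenyl: Compound 4 Expected

A few compounds are considered here, and "the series" means these few. Any claim that something is new, unique, unknown or untested is made for them only; others in the source may bear on it.

Three compounds have been measured in a functional assay on MCF7 cells (Homo sapiens) for cytotoxicity, read by MTT assay, with a stated time of 48 h; a lower number here means a stronger inhibitor, a higher number a weaker inhibitor:
compound 1 `O=C(Nc1ccc(Cl)cc1)c1cn(-c2ccccc2)nc1-c1ccccc1` gives 3860 nM;
compound 2 `O=C(Nc1ccc(Br)cc1)c1cn(-c2ccccc2)nc1-c1ccccc1` gives 5750 nM;
compound 3 `COc1ccc(NC(=O)c2cn(-c3ccccc3)nc2-c2ccccc2)cc1` gives 1710 nM.

Compound 3 holds the lowest number of the three in this assay. Its nearest neighbour is compound 1, with a 2.3-fold lower number from compound 1 to compound 3 (0.35 log units; beyond the scatter), and the gap to compound 2 is wider, with a 3.4-fold lower number from compound 2 to compound 3 (0.53 log units; beyond the scatter). Between compound 1 and compound 2 there is a 1.5-fold higher number from compound 1 to compound 2 (0.17 log units; within the scatter), so those two cannot be ordered.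

Compound 4 `COc1ccc(NC(=O)c2cn(-c3ccccc3)nc2-c2ccc(C)cc2)cc1` is compound 3 with a single change: methyl in place of hydrogen on an aromatic carbon. This change sits on the phenyl that hangs from the shared core, not on the amide-bearing ring where the three measured compounds differ from one another. Going by the values given here, none of the measured steps touches that phenyl, so no measured step bears directly on the change from compound 3 to compound 4. With nothing to point either way, the step is expected to stay within the scatter, and compound 4 is expected to give 1700 nM in this assay, most likely between 600 nM and 4500 nM. That expectation amounts to a 1.0-fold lower number from compound 3 to compound 4 (0.00 log units; within the scatter) relative to compound 3.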

Compound 4, half-maximal inhibitory concentration: 1620 nM
Compound 4: middle estimate off by 1.0-fold (0.02 log units), on the high side; the measured number falls inside the stated range.
By their numbers in this assay, from the lowest: compounds 4 and 3 (each within the scatter of the next); then compounds 1 and 2 (each within the scatter of the next).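

Going by these compounds alone, the earlier compounds differed only on the amide-bearing ring, so this is the first reading from the phenyl that hangs from the shared core: in this assay, the change from phenyl to 4-methylphenyl gives a 1.1-fold lower number from compound 3 to compound 4 (0.02 log units; within the scatter) and cannot be told apart from no change. This position, para to a large group, therefore accepts methyl in place of hydrogen with no readable shift in the number, whereas on the amide-bearing ring the methoxy steps from the chloro and bromo compounds were beyond the scatter. Nothing shown here offers an explanation for this lack of a readable shift.

As far as these compounds go, a single methyl samples only a small part of what this position might accept, so it remains open whether a longer chain such as butyl, an amine or a carboxylic acid at the same place would leave the number as flat. From the compounds shown here alone, it is also open whether the same methyl would read the same way with the chloro of compound 1 or the bromo of compound 2 on the amide-bearing ring, rather than the methoxy of compound 3.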